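Working notes on compounds 1 to 4 in cytotoxicity

The compounds below may be only part of what the source reports. "The series", "measured", "known", "first", "only" and "open" are said of these compounds alone.

Compound 2 `COc1ccc(-n2cc(-c3ccc(O)c(OC)c3)nn2)cc1` is the reference point. In a functional assay on MDA-MB-231 cells (Homo sapiens) for cytotoxicity, read by MTT assay (a lower number here means a stronger inhibitor, a higher number a weaker inhibitor), compound 2 gives > 10000 nM, which is a limit of the assay and not a number. Compound 3 `COc1ccc(-n2cc(-c3ccc(OC)c(OC)c3)nn2)cc1` carries methyl in place of hydrogen on an oxygen on an aromatic ring relative to compound 2. In this assay compound 3 gives > 100 nM, again a limit. Compound 1 `COc1ccc(-n2cc(-c3ccc(OC)c(OC)c3)nn2)cc1O` gives > 1000 nM in this assay, also a limit. Of the three values shown, one sits at the limit of > 100 nM in this assay, at which 1 of the 3 values shown sits, one at the limit of > 1000 nM in this assay, at which 1 of the 3 values shown sits, and one at the limit of > 10000 nM in this assay, at which 1 of the 3 values shown sits, so compound 2 stands at a limit among limits and no ordering of the three can be read.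

Compound 4 `COc1ccc(-n2cc(-c3ccc(O)c(OC)c3)nn2)cc1O` differs from compound 2 by hydroxy in place of hydrogen on an aromatic carbon. The steps that could bear on this change are a step that the two limits leave unreadable from compound 1 to compound 3 and a step that the two limits leave unreadable from compound 2 to compound 3; neither has a readable size. The same hydroxy in place of hydrogen, taken in reverse from compound 1 to compound 3, is hidden by two limits, so no direction can be drawn for this assay. Compound 4 is therefore expected to stay at a limit as well, with an estimate of 10000 nM and a range from 1000 nM to 50000 nM. This estimate implies a number no higher from compound 2 to compound 4 (the limit leaves the size open), expected to be none beyond the scatter.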

Compound 4, half-maximal inhibitory concentration: > 10000 nM
Compound 4: no number, only a limit; the forecaster's own chance of this, stated with the estimate: 80%; the middle value sits exactly at the limit.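

Compound 4, like compound 1 and compound 2, gives only a limit in this assay, and no new step can be read between compound 4 and either of the other two. The compounds shown leave open what size any single change on the shared core has, and how the four compounds truly order.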